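Dimethylamino on the phenyl ring of compound 2

The source may report more compounds than this note shows. Statements on the series, on what has been measured and on what is new or still open speak of the compounds shown alone.

Compound 1 `COc1cc(/C=C/C(=O)C2=C(/C=C/c3ccc(O)c(OC)c3)NC(=O)NC2c2c(Cl)cccc2Cl)ccc1O`: 31.9%
Compound 2 `COc1cc(/C=C/C(=O)C2=C(/C=C/c3ccc(O)c(OC)c3)NC(=S)NC2c2ccccc2)ccc1O`: 38%

Of the compounds shown here, two have been measured in a functional assay, with a stated time of 20 min, tested at 20 uM; on this read-out higher numbers stand for a stronger effect at the one concentration tested and lower numbers for a weaker effect. Compound 1 gives 31.9% in this assay, and compound 2 gives 38%. These two values lie within the scatter of each other, so on the numbers shown compound 2 cannot be set apart from compound 1.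

Compound 3 `COc1cc(/C=C/C(=O)C2=C(/C=C/c3ccc(O)c(OC)c3)NC(=S)NC2c2ccc(N(C)C)cc2)ccc1O` has not yet been measured. It differs from compound 2 in one place: dimethylamino in place of hydrogen on an aromatic carbon. Cut one bond further out, the same change reads phenyl to 4-(dimethylamino)phenyl, with the new group para to a large group. Within the data shown here, no measured pair shows what this change does in this assay. With nothing to lean on, the step expected is a number 2 percentage points higher from compound 2 to compound 3 (within the scatter), within the scatter and in no firm direction. Compound 3 is therefore estimated at 40%, with a range from 24% to 58%.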

Compound 3, a percentage reported as activity, at one concentration (the size of the read-out at that concentration, not a potency): 83%
Compound 3: the middle estimate sits 43 percentage points below what was measured; the measured number lies above the stated range.
By their numbers in this assay, from the lowest: compounds 1 and 2 (each within the scatter of the next); then compound 3.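

Putting dimethylamino in place of hydrogen, para to a large group, gives a number 45 percentage points higher from compound 2 to compound 3 (beyond the scatter) in this assay. This is the only single-place change shown so far, and it reveals that this aromatic carbon is far from indifferent: what sits there can strongly change the size of the read-out at the one concentration tested. No data shown here explain why the step is so large.

Among these compounds, with only one pair, it remains open whether this effect is specific to dimethylamino or would also appear with a plain amine, a methoxy group or the longer diethylamino group at the same carbon. On these data alone, it is also open whether dimethylamino would give a step of similar size on another carbon of the ring.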